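Halogen swap on a chalcone-type scaffold: chlorine to fluorine

This account rests on a few compounds, and the source may have more. Where it says the series, first, only, none or still open, it means among the compounds named here.

Measured so far:
compound 1, `COc1cc(-c2cc(/C=C/C(=O)c3ccc(Cl)c(Cl)c3)[nH]n2)cc(OC)c1OC`: 28%
compound 2, `COc1ccc(-c2cc(/C=C/C(=O)c3ccc(N)cc3)[nH]n2)cc1OC`: -73%
compound 3, `COc1cc(C(=O)/C=C/c2cc(-c3cc(OC)c(OC)c(OC)c3)n[nH]2)cc(OC)c1OC`: -80%

In a functional assay on SF-539 cells (Homo sapiens) for cytotoxicity, read by sulforhodamine B assay, with a stated time of 48 h, tested at 10 uM (on this read-out higher numbers stand for a weaker effect at the one concentration tested and lower numbers for a stronger effect), compound 1 gives 28%, the highest of the three numbers; compound 2 and compound 3 both lie far lower, beyond the scatter, so compound 1 shows the weakest effect of the set. Compound 4, `COc1cc(-c2cc(/C=C/C(=O)c3ccc(F)c(F)c3)[nH]n2)cc(OC)c1OC`, differs from compound 1 in one place: 3,4-difluorophenyl in place of 3,4-dichlorophenyl on a carbonyl carbon. Among the compounds with values here, no pair of measured compounds shows the effect of such a halogen exchange, so there is no step to lean on. The author expects the step of a number 3 percentage points lower from compound 1 to compound 4 (within the scatter) to stay small, with no clear direction beyond the scatter. Compound 4 is therefore estimated at 25%, within a range from -30% to 70%.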

Compound 4, a percentage reported as activity, at one concentration (the size of the read-out at that concentration, not a potency): 21%
For compound 4 the middle estimate is 4 percentage points above the measured one; the range from low to high includes it.
By their numbers in this assay, from the lowest: compounds 3 and 2 (each within the scatter of the next); then compounds 4 and 1 (each within the scatter of the next).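

In this assay, 3,4-difluorophenyl in place of 3,4-dichlorophenyl on a carbonyl carbon gives a number 7 percentage points lower from compound 1 to compound 4 (within the scatter) and so provides the first step read at this position. At this place on the shared core, this halogen exchange therefore does not move the read-out beyond the scatter. Nothing available explains why the step is this small. From the compounds shown here alone, it remains open whether a phenyl carrying a carboxylic acid or a nitrile on that carbonyl carbon would shift the read-out beyond the scatter. Going by these compounds, whether a bromine exchange would stay equally small is also open.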